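The source may hold more compounds than are shown below. What is called first, only, known or untested is meant among the compounds shown, and "the series" means these compounds.

Measured in a functional assay on MCF7 cells (Homo sapiens) for antiproliferative activity, read by sulforhodamine B assay, with a stated time of 48 h; a lower number here means a stronger inhibitor, a higher number a weaker inhibitor:
- compound 1 (`CO/N=C1/C(=O)N(CCCCCCC(=O)NO)c2ccccc21`) gives 1710 nM
- compound 2 (`CO/N=C1/C(=O)N(CCCCCCC(=O)NO)c2ccc(Cl)cc21`) gives 1560 nM
- compound 3 (`CO/N=C1/C(=O)N(CCCCCCC(=O)NO)c2ccc(C)cc21`) gives 16700 nM

Compound 1 stands level with compound 2, the step being a 1.1-fold lower number from compound 1 to compound 2 (0.04 log units; within the scatter), and compound 3 lies well above both.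

Compound 4 (`CO/N=C1/C(=O)N(CCCCCCC(=O)NO)c2c(Cl)cccc21`) differs from compound 1 by chloro in place of hydrogen on an aromatic carbon, with chloro in place of hydrogen on an aromatic carbon, ortho to a fused ring and meta to a fused ring. The nearest guide is the chloro of compound 2 on another aromatic carbon, a 1.1-fold lower number from compound 1 to compound 2 (0.04 log units; within the scatter). The methyl of compound 3 warns that one replacement can matter, a 9.8-fold higher number from compound 1 to compound 3 (0.99 log units; beyond the scatter). In this assay no step beyond the scatter is therefore expected, though a rise is the likelier risk. The expected step is a 1.2-fold higher number from compound 1 to compound 4 (0.07 log units; within the scatter). For compound 4 the estimated value is 2000 nM, within an expected range of 700 nM to 8000 nM.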

Compound 4, half-maximal inhibitory concentration: 340 nM
The estimate for compound 4 lay 5.9-fold (0.77 log units) above the measured number; the whole stated range lies above it.
By their numbers in this assay, from the lowest: compound 4; then compounds 2 and 1 (each within the scatter of the next); then compound 3.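

Chloro in place of hydrogen on this aromatic carbon, ortho to a fused ring and meta to a fused ring, strengthens the compound in this assay (a 5.0-fold lower number from compound 1 to compound 4 (0.70 log units; beyond the scatter)). The same replacement on another aromatic carbon left the number within the scatter (a 1.1-fold lower number from compound 1 to compound 2 (0.04 log units; within the scatter)), so among these compounds the outcome of adding chloro depends on where it sits. No measurement here accounts for this difference.

The compounds shown leave open whether fluoro, bromo, methoxy or an amine on this same carbon would match chloro. They also leave open whether methyl here would raise the number, as it does at its own position (a 9.8-fold higher number from compound 1 to compound 3 (0.99 log units; beyond the scatter)).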